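Fluorostilbene series: the step from compound 3 to compound 4

This account rests on a few compounds, and the source may have more. Where it says the series, first, only, none or still open, it means among the compounds named here.

Measured so far:
Compound 1, `Fc1cccc(/C=C/c2ccccc2)c1`: gives 3100 nM in an assay on HepG2 cells for activation of nuclear factor erythroid 2-related factor 2 (Homo sapiens), read by a luciferase reporter, with a stated time of 5 h; a higher number here means that more compound is needed for the effect, a lower number that less compound is needed.
Compound 2, `COc1cccc(/C=C/c2ccccc2F)c1`: gives 3800 nM in this assay.
Compound 3, `Fc1ccc(/C=C/c2ccccc2F)cc1F`: gives only a limit, > 15000 nM, in this assay.

Compound 3 thus stands at the limit of > 15000 nM in this assay, at which 1 of the 3 values shown sits; this is a limit of the assay and not a number. Compound 4, `Fc1cccc(/C=C/c2ccccc2F)c1`, is not yet measured. It differs from compound 3 by hydrogen in place of fluoro on an aromatic carbon. Going by the values given here, no measured pair differs in one place, so no measured step is at hand. Compound 1 and compound 2 each carry a single fluoro and lie within the usual scatter of one another in this assay. From compound 3 the step is expected to run toward less compound needed, an at least 4.2-fold lower number from compound 3 to compound 4 (0.63 log units; beyond the scatter), its size uncertain because compound 3 sits at > 15000 nM. Compound 4 is expected to give about 3500 nM in this assay, within 1500 nM to 10000 nM.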

Compound 4, half-maximal effective concentration: > 15000 nM
Compound 4: a limit, no number (the forecaster's own chance of this, stated with the estimate: 20%); at least 4.2-fold (0.63 log units) between middle value and limit.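

Compound 3 and compound 4 both rest on a limit, not a number, so the step between them cannot be read, and losing the fluoro ortho to a fluoro group brings no readable return: the limit of > 15000 nM in this assay, at which 2 of the 4 values shown sit.

Fluoro in place of hydrogen on an aromatic carbon gives an at least 4.8-fold higher number from compound 1 to compound 4 (0.68 log units; beyond the scatter). Fluoro in place of methoxy on an aromatic carbon gives an at least 3.9-fold higher number from compound 2 to compound 4 (0.59 log units; beyond the scatter), so at this place methoxy and hydrogen each give a measured value where fluoro gives only a limit.

Going by these compounds, how far compound 3 and compound 4 lie past the limit stays open. Also open, on these data alone, is whether an amine or a hydroxyl group at this place would give a measured value.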